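The compounds below may be only part of what the source reports. "The series", "measured", "known", "first", "only" and "open" are said of these compounds alone.

Working notes on the series, read in a functional assay on HUVEC cells (Homo sapiens), read by scintillation counting and thymidine incorporation, with a stated time of 24 h; a lower number here means a stronger inhibitor, a higher number a weaker inhibitor. Compound 1 `CCC(C)n1ncn(-c2ccc(N3CCN(c4ccc(OC[C@@H]5CO[C@@](Cc6ccccc6)(c6ccc(Cl)cc6Cl)O5)cc4)CC3)cc2)c1=O` gives 513 nM. Among the measured compounds shown here, compound 2 `CCC(C)n1ncn(-c2ccc(N3CCN(c4ccc(OC[C@@H]5CO[C@@](Cn6ccnc6C(C)C)(c6ccc(Cl)cc6Cl)O5)cc4)CC3)cc2)c1=O` gives 84 nM, the lower of the two numbers measured so far and so the stronger inhibitor of this pair. For the measured compounds named here, the only measured step, a 6.1-fold lower number from compound 1 to compound 2 (0.79 log units; beyond the scatter), came with 2-isopropyl-1H-imidazol-1-yl in place of phenyl on a saturated chain carbon bound to a saturated ring carbon.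

Compound 3 `CCC(C)n1ncn(-c2ccc(N3CCN(c4ccc(OC[C@@H]5CO[C@@](Cn6c(C)cnc6C)(c6ccc(Cl)cc6Cl)O5)cc4)CC3)cc2)c1=O` differs from compound 2 at that same place: 2,5-dimethyl-1H-imidazol-1-yl in place of 2-isopropyl-1H-imidazol-1-yl on a saturated chain carbon bound to a saturated ring carbon. Here 2,5-dimethyl-1H-imidazol-1-yl takes the place of 2-isopropyl-1H-imidazol-1-yl. The measured step bears on this only loosely, as it replaced phenyl, whereas here a 1H-imidazol-1-yl group stays and only its substituents differ. Going by the values given here, no measured step varies those substituents, so the direction is poorly defined by the data.

A change well short of the measured step is expected, most likely within the scatter, with a slight lean towards a higher number. The expected step is a 1.3-fold higher number from compound 2 to compound 3 (0.10 log units; within the scatter). The estimate for compound 3 is 105 nM, with an expected range of 40 nM to 280 nM.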

Compound 3, half-maximal inhibitory concentration: 765 nM
Beside the measured number, compound 3's estimate is 7.3-fold (0.86 log units) below it; the whole stated range lies below it.
By their numbers in this assay, from the lowest: compound 2; then compounds 1 and 3 (each within the scatter of the next).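

In this assay the substituents on the imidazole matter as much as the ring itself: with 2,5-dimethyl-1H-imidazol-1-yl in place of 2-isopropyl-1H-imidazol-1-yl on a saturated chain carbon bound to a saturated ring carbon, the series shows a 9.1-fold higher number from compound 2 to compound 3 (0.96 log units; beyond the scatter). Against the phenyl group the same 2,5-dimethyl-1H-imidazol-1-yl group gives a 1.5-fold higher number from compound 1 to compound 3 (0.17 log units; within the scatter), so a 1H-imidazol-1-yl ring at this place does not by itself bring the lower number of compound 2, and among the three groups shown that number goes only with 2-isopropyl-1H-imidazol-1-yl. The data shown offer no measurement that explains either step.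

The step from compound 2 to compound 3 changes the group at two points on the ring at once, so the compounds shown cannot separate the loss of the isopropyl group from the gain of the methyl group on the other ring carbon. From the compounds shown here alone, the unsubstituted 1H-imidazol-1-yl group, 2-methyl-1H-imidazol-1-yl and 2-isopropyl-5-methyl-1H-imidazol-1-yl would each divide that change, and how any of them would read here remains open.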